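From 3-hydroxyphenyl to 4-hydroxyphenyl: a step from a limit

The source may hold more compounds than are shown below. What is called first, only, known or untested is meant among the compounds shown, and "the series" means these compounds.

In a functional assay on ECa-109 cells for antiproliferative activity against ECa-109 cell line (Homo sapiens), read by MTT assay, with a stated time of 72 h (a higher number here means a weaker inhibitor, a lower number a stronger inhibitor), a lower number marks a stronger inhibitor, and compound 1 `C/C(=N\NC(=O)c1cccc(S(=O)(=O)N2CCOCC2)c1)c1ccccc1O` gives 5450 nM. Compound 2 `C/C(=N\NC(=O)c1cccc(S(=O)(=O)N2CCOCC2)c1)c1cccc(O)c1` gives > 100000 nM. From the compounds shown here alone, that value is a limit of the assay and not a number, so the true position of compound 2 on the scale stays open.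

The next compound changes the same group again. Compound 3 `C/C(=N\NC(=O)c1cccc(S(=O)(=O)N2CCOCC2)c1)c1ccc(O)cc1` carries 4-hydroxyphenyl in place of 3-hydroxyphenyl on a carbon with a double bond to nitrogen.

Among the measured compounds shown here, only one measured step bears on this change. With 3-hydroxyphenyl in place of 2-hydroxyphenyl, the number moves an at least 18-fold higher number from compound 1 to compound 2 (1.26 log units; beyond the scatter), a large change beyond the scatter. For the measured compounds named here, compound 3 also lacks 2-hydroxyphenyl, so it is expected to resemble compound 2 more than compound 1, although no measurement yet tests this.

In this assay, the expected step of an at least 1.1-fold lower number from compound 2 to compound 3 (0.04 log units; that floor lies within the scatter) is no larger than the scatter, with no clear direction. For compound 3 the estimated value is 90000 nM, with an expected range from 25000 nM to 200000 nM.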

Compound 3, half-maximal inhibitory concentration: 88300 nM
Compound 3: the middle estimate sits 1.0-fold (0.01 log units) above what was measured; low and high end bracket the measured number.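

Compound 3 turns the loss seen with 3-hydroxyphenyl from a limit into a measured number. In this assay, among the compounds shown here, 4-hydroxyphenyl in place of 2-hydroxyphenyl on the carbon with a double bond to nitrogen gives a 16-fold higher number from compound 1 to compound 3 (1.21 log units; beyond the scatter), so among the three compounds only the one with 2-hydroxyphenyl stands at the low end of this scale, and both other placements of the hydroxyl stand far from it. Against 3-hydroxyphenyl, the reading is only an at least 1.1-fold lower number from compound 2 to compound 3 (0.05 log units; that floor lies within the scatter), which gives no order between these two groups, and the value of compound 2 is a limit of the assay and not a number: the limit of > 100000 nM in this assay, at which 1 of the 3 values shown sits.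

Still open, from the compounds shown here alone, is whether the hydroxyl of 2-hydroxyphenyl is itself what matters, since a plain phenyl, or a methoxy group or an amine in its place, would show whether the number of compound 1 can be held without that hydroxyl. Going by these compounds, how far the true position of compound 2 lies from compound 3 also remains unknown, and the three compounds give no view of any change elsewhere on the shared core.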